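Lengthening an Ester Chain on a Shared Core

This account rests on a few compounds, and the source may have more. Where it says the series, first, only, none or still open, it means among the compounds named here.

Compound 1, `CCCCCCCOC(=O)CCC(=O)N1CCN(CCCOc2cc3c(Nc4ccc(F)c(Cl)c4)ncnc3cc2OC)CC1`: 79.9%
Compound 2, `CCCCCCCCCOC(=O)CCC(=O)N1CCN(CCCOc2cc3c(Nc4ccc(F)c(Cl)c4)ncnc3cc2OC)CC1`: 79.7%

In a functional assay on A549 cells (Homo sapiens) for cytotoxicity, read by MTT assay, with a stated time of 24 h, tested at 20 uM (on this read-out lower numbers stand for a stronger effect and higher numbers for a weaker effect at the one concentration tested), compound 1 gives 79.9% and compound 2 gives 79.7%. Compound 2 stands alongside compound 1: the step of a number 0.2 percentage points lower from compound 1 to compound 2 (within the scatter) is within the scatter, so the two numbers cannot be told apart, and neither compound can be called the more active of the pair.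

Compound 3, `CCCCCCCCCCCOC(=O)CCC(=O)N1CCN(CCCOc2cc3c(Nc4ccc(F)c(Cl)c4)ncnc3cc2OC)CC1`, differs from compound 2 by ethyl in place of hydrogen on a saturated chain carbon, nine bonds along the chain from an oxygen next to a carbonyl group. Among the compounds with values here, only one measured step bears on this change, a number 0.2 percentage points lower from compound 1 to compound 2 (within the scatter), which also put an ethyl onto the same saturated chain and lay within the scatter. Nothing here points in either direction, so the expected step is a number 0.2 percentage points lower from compound 2 to compound 3 (within the scatter), none beyond the scatter. Compound 3 is therefore estimated at 79.5%, with a range from 69% to 90%.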

Compound 3, a percentage reported as activity, at one concentration (the size of the read-out at that concentration, not a potency): 85.2%
Compound 3: the middle estimate sits 5.7 percentage points below what was measured; low and high end bracket the measured number.
By their numbers in this assay, from the lowest: compounds 2, 1 and 3 (each within the scatter of the next).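

In this assay, placing ethyl on the saturated chain carbon nine bonds along the chain from the oxygen gives a number 5.5 percentage points higher from compound 2 to compound 3 (within the scatter), while the butyl change counted from the shorter ester gives a number 5.3 percentage points higher from compound 1 to compound 3 (within the scatter). The new compound therefore extends the series without separating it: across all three chain lengths, the numbers cannot be told apart, and this position tolerates both the ethyl and the butyl change with no measurable shift in this read-out. No measured information bears on what lies behind these numbers.

As far as these compounds go, it remains open whether a longer chain, or an amine or a carboxylic acid at this place, would produce a step beyond the scatter. From the compounds shown here alone, all three numbers come from a single concentration, so how these compounds compare at other concentrations also remains open.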